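The compounds below may be only part of what the source reports. "The series", "measured", "known", "first", "only" and "open" are said of these compounds alone.

Compound 1 `CCN(CC)S(=O)(=O)c1ccc(S(=O)(=O)N2CCC[C@@H](C(=O)N(C)C(C)C)C2)cc1` gives 7700 nM in a functional assay on BXPC-3 cells (Homo sapiens) for inhibition, read by MTT assay, with a stated time of 7 days; a lower number here means a stronger inhibitor, a higher number a weaker inhibitor.
Compound 2 `CCOC(=O)N1CCC[C@H](S(=O)(=O)c2ccc(S(=O)(=O)N(CC)CC)cc2)C1` gives in this assay only a limit, > 30000 nM.

Within the data shown here, compound 1 therefore holds the only numbered value shown; the other entry sits at the limit of > 30000 nM in this assay, at which 1 of the 2 values shown sits. Compound 3 `CCN(CC)S(=O)(=O)c1ccc(S(=O)(=O)N2CCC[C@@H](C(=O)NC3CN(S(C)(=O)=O)C3)C2)cc1` differs from compound 1 by (1-(methylsulfonyl)azetidin-3-yl)amino in place of isopropyl(methyl)amino on a carbonyl carbon. Among the measured compounds shown here, no measured pair isolates a change of this kind, so its size is open, and a step no larger than the usual scatter, in either direction, is the expectation. Compound 3 is expected to give 8000 nM in this assay, somewhere between 2500 nM and 30000 nM. That amounts to an expected step of a 1.0-fold higher number from compound 1 to compound 3 (0.02 log units; within the scatter).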

Compound 3, half-maximal inhibitory concentration: 7400 nM
For compound 3 the middle estimate is 1.1-fold (0.03 log units) above the measured one; measured number inside the range.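

The swap gives a 1.0-fold lower number from compound 1 to compound 3 (0.02 log units; within the scatter) in this assay, so at this place on the carbonyl carbon, (1-(methylsulfonyl)azetidin-3-yl)amino, with its four-membered ring and amide hydrogen, reads the same as isopropyl(methyl)amino within the scatter. The earlier compounds shown here held no pair that isolated any change here. Nothing measured explains why the two groups read alike.

Still open, on these data alone, is whether any group at this place can move the number beyond the scatter. A carboxylic acid in place of the amide, or a longer chain on the amide nitrogen, would test that.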